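Para substituent swap on the cinnamamide thioether series

A few compounds are considered here, and "the series" means these few. Any claim that something is new, unique, unknown or untested is made for them only; others in the source may bear on it.

Measured so far:
- compound 1 `Cc1ccc(SCc2ccc(/C=C/C(=O)Nc3ccccc3N)cc2)cc1` gives 21.7%
- compound 2 `Nc1ccccc1NC(=O)c1ccc(CSc2nccc(C(F)(F)F)n2)cc1` gives 83.4%
- compound 3 `Nc1ccccc1NC(=O)c1ccc(CSc2ccc(Br)cc2)cc1` gives 38.2%

All three numbers come from a functional assay on HeLa cells (Homo sapiens) for inhibition, read by CCK-8 assay, with a stated time of 72 h, tested at 8 uM; on this read-out higher numbers stand for more inhibition of growth at the one concentration tested and lower numbers for less inhibition of growth. Compound 1 stands lowest of the three. The nearest number is that of compound 3, which lies higher by a margin beyond the scatter; compound 2 lies far higher, also beyond the scatter. Going by the values given here, compound 2 and compound 3 differ from compound 1 in more than one place, so no single step between measured compounds can be read from these values; their two values can only be set side by side.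

Compound 4 `Nc1ccccc1NC(=O)/C=C/c1ccc(CSc2ccc(F)cc2)cc1` is not yet measured in this assay. It differs from compound 1 in one place only: fluoro in place of methyl on an aromatic carbon. Among the compounds with values here, nothing among the measured compounds isolates this exchange, so no step size can be drawn from the data. With a change of one heavy atom for one heavy atom, with no ring and no change in donors, acceptors or charge, a step of no more than the scatter is expected in either direction from compound 1, on the low side of the three numbers seen. The expected step is a number 3.3 percentage points higher from compound 1 to compound 4 (within the scatter). For compound 4 the estimated growth inhibition is 25%, within a range from 10% to 42%.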

Compound 4, percent growth inhibition at one concentration: 10.4%
The estimate for compound 4 lay 14.6 percentage points above the measured number, within the range that was stated.
By their numbers in this assay, from the lowest: compound 4; then compound 1; then compound 3; then compound 2.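

In this assay, going by these compounds alone, the exchange of methyl for fluoro on an aromatic carbon para to a large group gives a number 11.3 percentage points lower from compound 1 to compound 4 (beyond the scatter) and is the first single-place change that can be read. The step is modest, but it shows that this position is not silent: replacing one heavy atom with one heavy atom, with no ring and no change in the counted donors, acceptors or charge, is enough to move growth inhibition past the usual scatter, and on the shared core 4-methylphenyl reads higher than 4-fluorophenyl. No measurement in hand bears on why this exchange lowers the number.

From the compounds shown here alone, a single exchange gives no trend at this position, so it remains open whether a methoxy group, an amine, a carboxylic acid or a longer chain such as ethyl or propyl on the same aromatic carbon would read above compound 1 or below compound 4. Steps from compound 2 and compound 3 to the other compounds cannot be read, as each differs from them in more than one place.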